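The source may hold more compounds than are shown below. What is called first, only, known or untested is meant among the compounds shown, and "the series" means these compounds.

Of the compounds shown here, three built on one shared core have been tested in a functional assay on the whole organism for inhibition, with Rattus norvegicus as the target, read by paw edema, with stated times of 30 min and 3 h, at a dose of 0.28 mmol/kg by the oral route; a lower number here means less inhibition, a higher number more inhibition at the dose given (going by the name of the read-out). Compound 1 `COc1ccc(-n2nc(C(N)=O)nc2-c2cc(OC)c(OC)c(OC)c2)cc1` gives 92%, and compound 2 `CNC(=O)c1nc(-c2cc(OC)c(OC)c(OC)c2)n(-c2ccc(OC)cc2)n1` gives 95%. The step of a number 3 percentage points higher from compound 1 to compound 2 (within the scatter) is within the scatter, so the two read as alike. Compound 3 `COc1ccc(-n2nc(C(=O)Nc3ccc(C)cc3)nc2-c2cc(OC)c(OC)c(OC)c2)cc1` gives 77%, the lowest of the three numbers. The steps of a number 15 percentage points lower from compound 1 to compound 3 (beyond the scatter) and a number 18 percentage points lower from compound 2 to compound 3 (beyond the scatter) are both beyond the scatter and both modest. Compound 4 `COc1ccc(-n2nc(C(=O)Nc3ccc(C(F)(F)F)cc3)nc2-c2cc(OC)c(OC)c(OC)c2)cc1` has not yet been measured. The change from compound 3 to compound 4 is trifluoromethyl in place of methyl on an aromatic carbon. For the measured compounds named here, the two measured steps that matter, a number 15 percentage points lower from compound 1 to compound 3 (beyond the scatter) and a number 18 percentage points lower from compound 2 to compound 3 (beyond the scatter), alter what sits on the amide-type nitrogen, not what sits on the aromatic carbon of the 4-methylphenyl; no measured pair varies that aromatic carbon. Going by the values given here, with no direct precedent, and with the nearest steps only modest, the change is expected to move the number little. Compound 4 is expected to give 75%, within 60% to 88%, an expected step of a number 2 percentage points lower from compound 3 to compound 4 (within the scatter) that would stay within the scatter.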

Compound 4, a percentage reported as inhibition, in the whole organism at one dose (the size of the read-out at that dose, not a potency): 83%
Compound 4: the middle estimate sits 8 percentage points below what was measured, and the stated range covers the measured number.
By their numbers in this assay, from the lowest: compounds 3, 4, 1 and 2 (each within the scatter of the next, the first and the last beyond it).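

In this assay, the first change made on the aromatic carbon para to a large group, trifluoromethyl in place of methyl, gives a number 6 percentage points higher from compound 3 to compound 4 (within the scatter), so this position accepts the swap without a change that can be told from scatter. With the new group in place, the larger amide substituent still costs something against the methyl amide, at a number 12 percentage points lower from compound 2 to compound 4 (beyond the scatter), but against the unsubstituted amide the result is a number 9 percentage points lower from compound 1 to compound 4 (within the scatter), so the loss seen with compound 3 relative to compound 1 is not clearly seen with compound 4. Nothing available explains these numbers.

From the compounds shown here alone, whether an amine or a carboxylic acid on that aromatic carbon would leave the number equally unmoved remains open. So does how a longer chain on the amide-type nitrogen would compare with the methyl of compound 2.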